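Losing the chloro group from the best compound so far

The source may hold more compounds than are shown below. What is called first, only, known or untested is meant among the compounds shown, and "the series" means these compounds.

Compound 1 `S=C(Nc1ccccc1)Nc1ccc2ncnc(Nc3cccc(Br)c3)c2c1` gives 10000 nM and compound 2 `S=C(Nc1ccc(Cl)cc1)Nc1ccc2ncnc(Nc3cccc(Br)c3)c2c1` gives 8200 nM in a functional assay on MDA-MB-231 cells (Homo sapiens) for inhibition, read by MTT assay, with a stated time of 48 h (on this read-out higher numbers stand for weaker inhibition of growth and lower numbers for stronger inhibition of growth), while compound 3 `FC(F)(F)c1cc(NC(=S)Nc2ccc3ncnc(Nc4cccc(Br)c4)c3c2)ccc1Cl` gives 1100 nM as the lowest number of the three. Compound 4 `FC(F)(F)c1ccc(NC(=S)Nc2ccc3ncnc(Nc4cccc(Br)c4)c3c2)cc1` differs from compound 3 by 4-(trifluoromethyl)phenyl in place of 4-chloro-3-(trifluoromethyl)phenyl on an amide-type nitrogen and has not yet been measured. Among the measured compounds shown here, two measured steps bear on this change. Adding chloro alone brought a 1.2-fold lower number from compound 1 to compound 2 (0.09 log units; within the scatter) while adding trifluoromethyl brought a 7.5-fold lower number from compound 2 to compound 3 (0.87 log units; beyond the scatter) on top of it. For the measured compounds named here, compound 4 keeps a trifluoromethyl group, yet no measured compound carries 4-(trifluoromethyl)phenyl, so part of that gain may be lost. A moderate upward move is expected, namely a 2.3-fold higher number from compound 3 to compound 4 (0.36 log units; beyond the scatter) in this estimate. Compound 4 is estimated at 2500 nM with an expected range from 900 nM to 8000 nM for the measurement.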

Compound 4, concentration for 50% growth inhibition: 12200 nM
The estimate for compound 4 lay 4.9-fold (0.69 log units) below the measured number; measured number outside the range, above it.
By their numbers in this assay, from the lowest: compound 3; then compounds 2, 1 and 4 (each within the scatter of the next).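

Taking the chloro group off compound 3 gives up its lead, with an 11-fold higher number from compound 3 to compound 4 (1.04 log units; beyond the scatter). Compound 4 stays level with the two weaker compounds, with a 1.5-fold higher number from compound 2 to compound 4 (0.17 log units; within the scatter) and a 1.2-fold higher number from compound 1 to compound 4 (0.09 log units; within the scatter), so 4-(trifluoromethyl)phenyl offers no gain on its own. Trifluoromethyl lowered the number only with chloro on the same ring: the same change on two cores in this assay, a 7.5-fold lower number (0.87 log units; beyond the scatter) from compound 2 to compound 3 and a 1.2-fold higher number (0.09 log units; within the scatter) from compound 1 to compound 4, 9.1-fold (0.96 log units) apart, beyond the scatter of two such steps.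

From the compounds shown here alone, whether another group, such as fluoro or methoxy, could take the place of chloro in compound 3 and keep its low number remains open.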